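The compounds below may be only part of what the source reports. "The series", "measured", "known", "first", "only" and "open" are said of these compounds alone.

Working notes on the series. All three measured compounds share one core and are varied only on the saturated chain carbon bound to an aromatic nitrogen. Compound 1 `Cn1nc(-c2cccnc2)c2ccccc2c1=O` gives 63% in an assay on isolated protein (Oryctolagus cuniculus) with Thromboxane-A synthase (Homo sapiens) as the target, tested at 1 uM; a higher number here means more inhibition at the concentration tested (going by the name of the read-out), a lower number less inhibition. Compound 2 `C=CCn1nc(-c2cccnc2)c2ccccc2c1=O` gives 70% in this assay. Compound 3 `COCCn1nc(-c2cccnc2)c2ccccc2c1=O` gives 55% in this assay, the lowest of the three numbers; the gap a number 8 percentage points lower from compound 1 to compound 3 (within the scatter) lies within the scatter, while a number 15 percentage points lower from compound 2 to compound 3 (beyond the scatter) lies beyond it.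

Compound 4 `O=C(O)c1ccc(Cn2nc(-c3cccnc3)c3ccccc3c2=O)cc1` is not yet measured. Its change from compound 3: 4-carboxyphenyl in place of methoxymethyl on a saturated chain carbon bound to an aromatic nitrogen.

Among the compounds with values here, the steps that bear on this sit at the same place: a number 7 percentage points higher from compound 1 to compound 2 (within the scatter) and a number 8 percentage points lower from compound 1 to compound 3 (within the scatter) are both within the scatter, and only a number 15 percentage points lower from compound 2 to compound 3 (beyond the scatter) is modest. Within the data shown here, none of them brings in a ring, so the 4-carboxyphenyl group has no close precedent here. The recorded changes at this position have all been small, so no step beyond the scatter in this assay is expected in either direction, though the range must stay wide.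

Compound 4 is therefore estimated at 58%, between 35% and 80%. The expected step is a number 3 percentage points higher from compound 3 to compound 4 (within the scatter).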

Compound 4, a percentage reported as inhibition, at one concentration (the size of the read-out at that concentration, not a potency): 64%
Compound 4: middle estimate off by 6 percentage points, on the low side, within the range that was stated.
By their numbers in this assay, from the lowest: compounds 3, 1, 4 and 2 (each within the scatter of the next, the first and the last beyond it).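

Compound 4 is the only one of the series with a ring on the saturated chain carbon bound to an aromatic nitrogen, and in this assay all its steps stay within the scatter (a number 9 percentage points higher from compound 3 to compound 4 (within the scatter); a number 6 percentage points lower from compound 2 to compound 4 (within the scatter); a number 1 percentage points higher from compound 1 to compound 4 (within the scatter)). The position therefore takes 4-carboxyphenyl, with 9 heavy atoms against the 3 of methoxymethyl, without a step beyond the scatter from any of the three earlier compounds. Nothing measured here explains this result.

The compounds shown leave open whether the aromatic ring or the carboxylic acid on it sets this number, a question that an unsubstituted phenyl or a methyl ester in place of 4-carboxyphenyl would address. Also open, on these data alone, is how an amine on the same ring, or a longer chain carrying the carboxylic acid, would read in this assay at this position.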